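Capping a Ring Amine with Benzyloxycarbonyl

A few compounds are considered here, and "the series" means these few. Any claim that something is new, unique, unknown or untested is made for them only; others in the source may bear on it.

Compound 2 `S=C(SCc1cn(Cc2ccc(Cl)c(Cl)c2)nn1)N1CCNCC1` stands without a number in a functional assay on PC-3 cells (Homo sapiens) for inhibition, read by MTT assay, with a stated time of 72 h; a lower number here means a stronger inhibitor, a higher number a weaker inhibitor; for compound 2 the outcome is "not determined" (no result reported). Compound 1 `O=C(OCc1ccccc1)N1CCN(C(=S)SCc2cn(Cc3ccc(F)cc3)nn2)CC1` carries the same cap on its ring nitrogen. Compound 1 reaches only a limit of this assay, > 128000 nM. Compound 3 `O=C(OCc1ccccc1)N1CCN(C(=S)SCc2cn(Cc3ccc(Cl)c(Cl)c3)nn2)CC1` differs from compound 2 by benzyloxycarbonyl in place of hydrogen on an amine nitrogen in a ring. Within the data shown here, with no measured step to lean on, the change is expected to move this assay little, if at all, beyond the usual scatter, and a weak outcome seems likely given (the limit of > 128000 nM in this assay, at which 1 of the 2 values shown sits). Compound 3 is estimated at 100000 nM, between 30000 nM and 300000 nM.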

Compound 3, half-maximal inhibitory concentration: > 128000 nM
Compound 3 was reported as a limit (the forecaster's own chance of this, stated with the estimate: 70%); middle value at least 1.2-fold (0.10 log units) from the limit.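

Compound 1 and compound 3 both end at a limit in this assay, and compound 2 has no number, so no step can be read. On these data alone, what the benzyloxycarbonyl cap or the change of aryl group does to inhibition stays open.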